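This account rests on a few compounds, and the source may have more. Where it says the series, first, only, none or still open, it means among the compounds named here.

In an ADME assay on the whole organism (strain CD-1) for metabolic stability, with Mus musculus as the target, at a dose of 50 mg/kg by the oral route (on this read-out lower numbers stand for a shorter-lived compound and higher numbers for a longer-lived compound), compound 2 `O=C(N[C@@H]1C[C@@H](C(=O)NC[C@@H]2CC(Br)=NO2)N(C(=O)OCc2cnc3ccccc3c2)C1)c1ccc(O)cc1` gives 0.25 h, level with compound 1 `O=C(NC[C@@H]1CC(Br)=NO1)[C@@H]1C[C@@H](c2ccc(O)cc2)CN1C(=O)OCc1cnc2ccccc2c1` at 0.25 h. The next structure, compound 3 `O=C(NC[C@@H]1CC(Br)=NO1)[C@@H]1C[C@@H](c2ccccc2)CN1C(=O)OCc1cnc2ccccc2c1`, keeps the shared core and alters one group, on a saturated ring carbon of a five-membered non-aromatic ring with 1 nitrogen: phenyl in place of ((4-hydroxyphenyl)carbonyl)amino (phenyl in place of ((4-hydroxyphenyl)carbonyl)amino on a saturated ring carbon). Among the compounds with values here, only one measured step bears on this, and it was made at the same place: 4-hydroxyphenyl gave way to ((4-hydroxyphenyl)carbonyl)amino, with no change at the digits printed from compound 1 to compound 2 (within the scatter). Within the data shown here, that single step lies within the scatter, and no measured compound yet carries plain phenyl there, so the evidence is thin. Even so, no step beyond the scatter is expected in this assay, in either direction. The expected outcome is no change at the digits printed from compound 2 to compound 3 (within the scatter). Compound 3 is expected at 0.25 h, with an estimated range from 0.12 h to 0.5 h.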

Compound 3, half-life: 0.25 h
Compound 3: middle estimate and measured number agree at the digits printed; the measured number falls inside the stated range.
By their numbers in this assay, from the lowest: compounds 1, 2 and 3 (each within the scatter of the next).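

this assay shows no change at the digits printed from compound 2 to compound 3 (within the scatter) when phenyl replaces the larger ((4-hydroxyphenyl)carbonyl)amino on this saturated ring carbon, two ring bonds from the ring nitrogen. Within the data shown here, compound 3 also gives the first direct look at the hydroxy group alone, and hydrogen in place of hydroxy on an aromatic carbon gives no change at the digits printed from compound 1 to compound 3 (within the scatter) in the same read-out. Among these compounds, then, neither swap at this site separates the half-lives, and nothing measured here says what sets their shared level.

Going by these compounds, it remains open whether an amine or a carboxylic acid on this ring carbon would shift the half-life beyond the scatter. The same question stands for a longer chain at this site, or for a fluorine atom on the phenyl ring.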